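This account rests on a few compounds, and the source may have more. Where it says the series, first, only, none or still open, it means among the compounds named here.

The measured compounds:
compound 1 `O=C(/C=C\c1ccccc1O)N1N=C(c2ccncc2)OC1c1c[nH]c2ccccc12`: > 30 ug/mL
compound 2 `O=C(/C=C\c1cccc(O)c1)N1N=C(c2ccncc2)OC1c1c[nH]c2ccccc12`: > 30 ug/mL
compound 3 `O=C(/C=C\c1ccc([N+](=O)[O-])cc1)N1N=C(c2ccncc2)OC1c1c[nH]c2ccccc12`: > 30 ug/mL

In an ADME assay on PANC-1 cells (Homo sapiens) for cytotoxicity, read by MTT assay, with a stated time of 48 h (a higher number here means a weaker inhibitor of growth, a lower number a stronger inhibitor of growth), compound 1 gives > 30 ug/mL, which is a limit of the assay and not a number. Compound 2 likewise gives only the limit > 30 ug/mL. Compound 3 also gives only the limit > 30 ug/mL. Compound 1 therefore stands where every measured compound stands: the limit of > 30 ug/mL in this assay, at which 3 of the 3 values shown sit.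

Compound 4 `COc1ccc(/C=C\C(=O)N2N=C(c3ccncc3)OC2c2c[nH]c3ccccc23)cc1` differs from compound 1 by 4-methoxyphenyl in place of 2-hydroxyphenyl on a double-bonded chain carbon bound to a double-bonded chain carbon. The measured steps that change the same phenyl group on the same carbon are a step that the two limits leave unreadable from compound 1 to compound 2 and a step that the two limits leave unreadable from compound 1 to compound 3, and in both cases the two limits leave the size unreadable. No readable step is available in this assay, so no direction or size of change can be derived; the one pattern visible is that every variation of this phenyl group has returned a limit.

Compound 4 is expected to give 40 ug/mL in this assay, estimated between 15 ug/mL and 120 ug/mL. That estimate corresponds to an expected step that the limit leaves unreadable from compound 1 to compound 4, with another limit the most likely report.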

Compound 4, concentration for 50% growth inhibition: > 30 ug/mL
Compound 4: only a limit was reported (the forecaster's own chance of this, stated with the estimate: 75%); the middle value is on the limit's open side.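

Among the compounds shown here, compound 4 returns only a limit of the assay, just as compound 1, compound 2 and compound 3 do, so no step among them can be read: the limit of > 30 ug/mL in this assay, at which 4 of the 4 values shown sit.

The compounds shown leave open how strongly each inhibits growth in this assay, and whether changing this phenyl group alters that strength at all.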